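Swapping Fluoro for Chloro on a Dichloroacetamide

The compounds below may be only part of what the source reports. "The series", "measured", "known", "first", "only" and "open" are said of these compounds alone.

Measured so far in a functional assay on A549 cells (Homo sapiens) for cytotoxicity, read by MTT assay, with a stated time of 68 h; a lower number here means a stronger inhibitor, a higher number a weaker inhibitor:
compound 1, `O=C(Nc1cccc(-c2ccc(F)cc2)c1)C(Cl)Cl`, gives 7840 nM.
compound 2, `CSc1cccc(-c2cc(NC(=O)C(Cl)Cl)cc(-c3cccc(SC)c3)c2)c1`, gives 15900 nM.
compound 3, `O=C(Nc1cccc(-c2cccc(F)c2)c1)C(Cl)Cl`, gives 9530 nM.

Compound 1 holds the lowest of these three numbers. Its gap to compound 3 lies within the usual scatter, so the two cannot be told apart; its gap to compound 2 lies beyond it. Compound 4, `O=C(Nc1cccc(-c2ccc(Cl)cc2)c1)C(Cl)Cl`, differs from compound 1 in one place: chloro in place of fluoro on an aromatic carbon. Going by the values given here, no measured pair shows this exact change, so there is no directly comparable step to lean on. In this assay the step is expected to be small, perhaps a modest move toward a lower number, and possibly none beyond the scatter. Compound 4 is therefore estimated at 6000 nM, with a range from 2500 nM to 15000 nM. That corresponds to an expected 1.3-fold lower number from compound 1 to compound 4 (0.12 log units; within the scatter).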

Compound 4, half-maximal inhibitory concentration: 36200 nM
Estimate against measurement, compound 4: 6.0-fold (0.78 log units) below; the whole stated range lies below it.
By their numbers in this assay, from the lowest: compounds 1, 3 and 2 (each within the scatter of the next, the first and the last beyond it); then compound 4.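

In this assay, chloro in place of fluoro on this aromatic carbon, para to a large group, gives a 4.6-fold higher number from compound 1 to compound 4 (0.66 log units; beyond the scatter). Going by these compounds alone, this position therefore does not treat the two halogens alike, something compounds 1, 2 and 3 could not show, since no pair among them differs in one place. Nothing measured here explains the difference. As far as these compounds go, whether a hydrogen, a methoxy group or a trifluoromethyl group at this position would give a lower or a higher number remains open. So does whether the same swap would have a similar effect elsewhere on the ring.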